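Methoxy for Fluoro on the Aryl Arm of Compound 3

The compounds below may be only part of what the source reports. "The series", "measured", "known", "first", "only" and "open" are said of these compounds alone.

Of the compounds shown here, three sharing one core have been tested in a functional assay on ACHN cells (Homo sapiens) for cytotoxicity, read by MTT assay, with a stated time of 48 h; on this read-out lower numbers stand for stronger inhibition and higher numbers for weaker inhibition. Compound 1 `COc1ccc(-c2cc(C(=O)Nc3nc4ccc(Cl)cc4s3)nc3cc(-c4ccccc4)nn23)cc1` gives 7240 nM. Compound 2 `COc1ccc(-c2cc(C(=O)Nc3nc4ccc(F)cc4s3)nc3cc(-c4ccccc4)nn23)cc1` gives 39300 nM; the single difference between the two is the step of a 5.4-fold higher number from compound 1 to compound 2 (0.73 log units; beyond the scatter). Compound 3 `Cc1cc2nc(NC(=O)c3cc(-c4ccc(F)cc4)n4nc(-c5ccccc5)cc4n3)sc2cc1C` gives 33000 nM, which places it second highest of the three numbers: its gap to compound 2 lies within the scatter, while the gap to compound 1, which sits lower, lies beyond it.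

Compound 4 `COc1ccc(-c2cc(C(=O)Nc3nc4cc(C)c(C)cc4s3)nc3cc(-c4ccccc4)nn23)cc1` differs from compound 3 only in this change: methoxy in place of fluoro on an aromatic carbon. Within the data shown here, no measured pair isolates this change. Among the measured compounds shown here, the one measured step, from compound 1 to compound 2, concerns a halogen swap on a different part of the molecule and says nothing about the aryl substituent. For the measured compounds named here, with no step that bears on it, the expectation for compound 4 is a change no larger than the scatter, a 1.3-fold lower number from compound 3 to compound 4 (0.12 log units; within the scatter). Compound 4 is therefore estimated at 25000 nM, within a range from 8000 nM to 70000 nM.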

Compound 4, half-maximal inhibitory concentration: 22400 nM
Compound 4: middle estimate off by 1.1-fold (0.05 log units), on the high side; the measured number falls inside the stated range.
By their numbers in this assay, from the lowest: compound 1; then compounds 4, 3 and 2 (each within the scatter of the next).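

Among these compounds, the 4-fluorophenyl to 4-methoxyphenyl swap can now be read directly for the first time: in this assay it gives a 1.5-fold lower number from compound 3 to compound 4 (0.17 log units; within the scatter), so, on the 5,6-dimethyl-1,3-benzothiazol-2-yl amide, this position tolerates either fluoro or methoxy without a change beyond the scatter. With the 4-methoxyphenyl arm held constant, the amide-nitrogen group also separates two cases: 5,6-dimethyl-1,3-benzothiazol-2-yl in place of 6-fluoro-1,3-benzothiazol-2-yl gives a 1.8-fold lower number from compound 2 to compound 4 (0.24 log units; within the scatter), while in place of 6-chloro-1,3-benzothiazol-2-yl it gives a 3.1-fold higher number from compound 1 to compound 4 (0.49 log units; beyond the scatter), leaving the chloro compound apart. No accompanying measurement offers an explanation for these differences.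

Among the compounds shown here, the swap has been seen on only one amide group, so whether it would behave the same way alongside the 6-chloro group remains open. Also open, on these data alone, is whether an amine or a carboxylic acid on this aromatic carbon would move the number beyond the scatter.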